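Dichlorophenyl urea analogue of a quinoline diaryl ether series

The compounds below may be only part of what the source reports. "The series", "measured", "known", "first", "only" and "open" are said of these compounds alone.

Measured compounds:
compound 1, `COc1cc2cc(Oc3ccc(NC(=O)Nc4ccccc4)cc3)c(C)nc2cc1OC`, 88.7%
compound 2, `COc1cc2cc(Oc3ccc(NC(=O)Nc4ccc(C(F)(F)F)cc4)cc3)c(C)nc2cc1OC`, 70.4%
compound 3, `COc1cc2cc(Oc3ccc(NC(=O)Nc4cccc(C(F)(F)F)c4)cc3)c(C)nc2cc1OC`, 9.13%

In a functional assay on CAKI-1 cells (Homo sapiens) for inhibition, read by sulforhodamine B assay, with a stated time of 48 h, tested at 10 uM (on this read-out higher numbers stand for a weaker effect at the one concentration tested and lower numbers for a stronger effect), compound 3 gives 9.13%, the lowest of the three numbers and therefore the strongest effect among them; its nearest neighbour is compound 2 with 70.4%, and compound 1 lies furthest away with 88.7%. The unmeasured compound 4, `COc1cc2cc(Oc3ccc(NC(=O)Nc4ccc(Cl)c(Cl)c4)cc3)c(C)nc2cc1OC`, differs from compound 3 only at the phenyl group on the urea: 3,4-dichlorophenyl in place of 3-(trifluoromethyl)phenyl on an amide-type nitrogen.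

For the measured compounds named here, three measured steps bear on this part of the molecule. Adding a trifluoromethyl group gave a number 18.3 percentage points lower from compound 1 to compound 2 (beyond the scatter) and, with the group in the other arrangement, a number 79.6 percentage points lower from compound 1 to compound 3 (beyond the scatter); moving it between the two arrangements gave a number 61.3 percentage points lower from compound 2 to compound 3 (beyond the scatter). Going by the values given here, no measured step involves chlorine, so the effect of the two chlorine atoms is not known from these data. Since a substituted phenyl group has so far given the lowest numbers, compound 4 is expected to remain at the low end, with a step of a number 10.9 percentage points higher from compound 3 to compound 4 (beyond the scatter) that may fall within the scatter. Compound 4 is therefore estimated at 20% in this assay, between 3% and 55%.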

Compound 4, a percentage reported as activity, at one concentration (the size of the read-out at that concentration, not a potency): 21.8%
For compound 4 the middle estimate is 1.8 percentage points below the measured one, and the stated range covers the measured number.
By their numbers in this assay, from the lowest: compound 3; then compound 4; then compound 2; then compound 1.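

In this assay, the result for compound 4 shows that a strong effect at this amide-type nitrogen does not depend on a trifluoromethyl group: 3,4-dichlorophenyl in place of phenyl gives a large change (a number 66.9 percentage points lower from compound 1 to compound 4 (beyond the scatter)), and in place of 4-(trifluoromethyl)phenyl another large change (a number 48.6 percentage points lower from compound 2 to compound 4 (beyond the scatter)). The 3-(trifluoromethyl)phenyl group of compound 3 still keeps the edge over 3,4-dichlorophenyl, though the step between them is only modest (a number 12.7 percentage points higher from compound 3 to compound 4 (beyond the scatter)), so among these four compounds the position of the substituents on the phenyl group counts for more than the swap of trifluoromethyl for two chlorine atoms, with the wide gap of compound 2 from compound 3 and compound 4 as the clearest sign. Nothing available here accounts for why these phenyl groups differ.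

Still open, from the compounds shown here alone, is how a single chlorine on the phenyl group would compare with the two in compound 4, and whether a methoxy group, a nitrile or an amine there would keep the number as low as in compound 3. Also open, going by these compounds, is whether the same order of phenyl groups would hold if the methyl group on the shared core gave way to a longer chain such as ethyl.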